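Moving the Chlorine Along the Benzyl Group

This account rests on a few compounds, and the source may have more. Where it says the series, first, only, none or still open, it means among the compounds named here.

Compound 2 `CC1=C(C(=O)Nc2ccc([N+](=O)[O-])cc2)C(c2ccc(Br)cc2)N=C(SCc2ccccc2Cl)N1` gives the lowest of the two numbers in a functional assay on the whole organism (artery, strain albino) with Rattus norvegicus as the target, with a stated time of 180 min, at a dose of 10 mg/kg by the oral route (on this read-out lower numbers stand for less inhibition and higher numbers for more inhibition at the one dose given (going by the name of the read-out)), with 11.3%. For the measured compounds named here, its only neighbour, compound 1 `CC1=C(C(=O)Nc2ccc([N+](=O)[O-])cc2)C(c2ccc(Br)cc2)N=C(SCc2ccccc2)N1`, gives 19.6% in this assay; the single measured step, a number 8.3 percentage points lower from compound 1 to compound 2 (within the scatter), stays within the scatter. Compound 3 `CC1=C(C(=O)Nc2ccc([N+](=O)[O-])cc2)C(c2ccc(Br)cc2)N=C(SCc2cccc(Cl)c2)N1` differs from compound 2 by 3-chlorophenyl in place of 2-chlorophenyl on a saturated chain carbon bound to a sulfur. Going by the values given here, no measured step moves a chlorine from one place on this ring to another, and the one step that added a chlorine changed little. I therefore expect compound 3 to shift only a number 3.7 percentage points higher from compound 2 to compound 3 (within the scatter) in this assay, with no firm direction. My estimate for compound 3 is 15%, between 5% and 28%.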

Compound 3, a percentage reported as inhibition, in the whole organism at one dose (the size of the read-out at that dose, not a potency): 9.3%
The estimate for compound 3 lay 5.7 percentage points above the measured number, and the stated range covers the measured number.
By their numbers in this assay, from the lowest: compounds 3, 2 and 1 (each within the scatter of the next, the first and the last beyond it).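

In this assay, the move from 2-chlorophenyl to 3-chlorophenyl gives a number 2 percentage points lower from compound 2 to compound 3 (within the scatter), so the two chlorine placings cannot be told apart. Set against the unsubstituted benzyl group, the 3-chlorobenzyl group gives a number 10.3 percentage points lower from compound 1 to compound 3 (beyond the scatter), a modest change and the only step so far to clear the scatter. Nothing available explains this small difference. Still open, on these data alone, is whether a methoxy group or a fluorine in place of the chlorine would behave the same way, and what a longer chain in place of the benzyl group would do.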